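Adding a chloro to the pyridinyloxy side chain

A few compounds are considered here, and "the series" means these few. Any claim that something is new, unique, unknown or untested is made for them only; others in the source may bear on it.

Measured compounds:
Compound 1, `Cc1ccc(Oc2ccc3nc(COc4cccc(C(=O)O)c4)n(C)c3n2)cc1`, gives 1.7 in a physicochemical assay for lipophilicity, read by LC-MS, in phosphate buffer, measured as octanol-water partition, with a stated time of 30 min, at pH 7.4, tested at 200 mM; on this read-out lower numbers stand for lower lipophilicity and higher numbers for higher lipophilicity.
Compound 2, `Cn1c(COc2cccc(C(=O)O)c2)nc2ccc(Oc3ccccn3)cc21`, gives 0.4 in this assay.

Of the two numbers recorded, compound 2 stands lowest, and its nearest neighbour is compound 1, which lies higher by a gap beyond the usual scatter of repeated measurements. Within the data shown here, the two compounds differ in more than one place, so their values are simply two points and no single step is attached to the pair.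

The next compound, compound 3, `Cn1c(COc2cccc(C(=O)O)c2)nc2ccc(Oc3cc(Cl)ccn3)cc21`, arises from compound 2 by a single change: chloro in place of hydrogen on an aromatic carbon. Among the measured compounds shown here, no step between measured compounds is available to calibrate this change, so the expectation rests on the change alone. An upward step of moderate size, clearly beyond the scatter, is expected from compound 2 to compound 3, written as a number 0.60 log units higher from compound 2 to compound 3 (beyond the scatter). Compound 3 is therefore expected to give about 1 in this assay, with a likely range from 0.5 to 1.5.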

Compound 3, distribution coefficient: 1.2
Compound 3: middle estimate off by 0.20 log units, on the low side, within the range that was stated.
By their numbers in this assay, from the lowest: compound 2; then compound 3; then compound 1.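

In this assay, putting a chloro on the aromatic carbon opposite the ring nitrogen, which turns the pyridin-2-yl group into 4-chloropyridin-2-yl, gives a number 0.80 log units higher from compound 2 to compound 3 (beyond the scatter). Among these compounds, this is the first step in the set that belongs to a single change, since the two earlier compounds differ in more than one place and could not tie any shift in the number to one spot. It shows that this position on the side chain can take a single heavy atom in place of hydrogen and move the read-out by more than repeat measurements would, although no measurement shown here explains why the number moves.

One step at one position still leaves open how far the result extends to other groups, such as a fluoro, a methoxy, a nitrile or an amine on the same carbon, and whether any of them would shift the number in the same direction. From the compounds shown here alone, it also remains open whether a chloro on a different carbon of this ring, or on the same carbon with a different group elsewhere on the shared core, would give a step of similar size.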